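A few compounds are considered here, and "the series" means these few. Any claim that something is new, unique, unknown or untested is made for them only; others in the source may bear on it.

Measured so far in a functional assay on WiDr cells (Homo sapiens) for cytotoxicity, read by MTT assay, tested at 10 ug/mL; a higher number here means more inhibition at the concentration tested (going by the name of the read-out), a lower number less inhibition:
compound 1, `C/C1=C/CC/C(C)=C/C(=O)CC2=C[C@@H](OC2=O)[C@@H](C(C)C)CC1=O`, gives 20%
compound 2, `C/C1=C\C(=O)CC2=C[C@@H](OC2=O)[C@@H](C(C)C)CC(=O)/C(C)=C/CC1`, gives 19.4%

Compound 2 holds the lower of the two numbers, but the step between them is a number 0.6 percentage points lower from compound 1 to compound 2 (within the scatter), so no order between the two compounds can be read from this assay. The change from compound 2 to compound 3, `C/C1=C/C(=O)CC2=C[C@@H](OC2=O)[C@H](C(C)C)CC(=O)/C(C)=C/CC1`, is the two compounds have the same atoms and bonds and differ only in configuration as drawn: 2 of 4 stereo elements differ; a stereocentre at a saturated ring carbon is drawn R in compound 2 and S in compound 3; a double bond is drawn E in compound 2 and Z in compound 3. Within the data shown here, the only measured step that bears on this is the one from compound 1 to compound 2, where a double bond drawn Z became E and the result was a number 0.6 percentage points lower from compound 1 to compound 2 (within the scatter); that the two compounds differ only in configuration as drawn the fact that compounds 1 and 2 differ only in the configuration as drawn ties that step to the double-bond geometry alone. Among the measured compounds shown here, the stereocentre at the saturated ring carbon has no measured counterpart among the two compounds, so its weight cannot be set from these numbers and widens the range. In this assay the expected step is a number 0.6 percentage points higher from compound 2 to compound 3 (within the scatter), none beyond the scatter. Compound 3 is therefore estimated in this assay at 20%, within 8% to 35%.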

Compound 3, a percentage reported as inhibition, at one concentration (the size of the read-out at that concentration, not a potency): 29.1%
For compound 3 the middle estimate is 9.1 percentage points below the measured one; the measured number falls inside the stated range.
By their numbers in this assay, from the lowest: compounds 2, 1 and 3 (each within the scatter of the next).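

In this assay, the stereocentre at the saturated ring carbon now has a measured case, but only together with a double bond drawn E in compound 2 and Z in compound 3, and the pair gives a number 9.7 percentage points higher from compound 2 to compound 3 (within the scatter). Among these compounds, with three stereo elements differing, among them two double bonds, the result is a number 9.1 percentage points higher from compound 1 to compound 3 (within the scatter), so this wider difference in configuration also separates no compounds in this assay. The stereocentre and the double bond go together in both steps, so their separate shares cannot be read, and the comparison of compound 2 with compound 3 rests on configuration alone: the fact that compounds 2 and 3 differ only in the configuration as drawn

Among the compounds shown here, whether the stereocentre alone counts for anything in this assay stays open, as no pair here differs in that element only. As far as these compounds go, all three compounds have the same atoms and bonds, so the effect of a different group on the shared core, such as an amine or a carboxylic acid, also stays open.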